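Swapping the Acid for a Morpholine Amide

The compounds below may be only part of what the source reports. "The series", "measured", "known", "first", "only" and "open" are said of these compounds alone.

Two compounds share a core in which a pyridine-linked vinyl carbonyl carries a different terminal group. Compound 1 `COC1CN(C(=O)/C=C/c2ccncc2-c2ccc3[nH]ncc3c2)C1` ends in a cyclic amide; compound 2 `Cn1ccc2cc(-c3cnccc3/C=C/C(=O)O)ccc21` ends in a free carboxylic acid. In an assay on a protein complex for inhibition of CDK8/Cyclin C (Homo sapiens), with a stated time of 1 h, tested at 10 uM (a higher number here means more inhibition at the concentration tested (going by the name of the read-out), a lower number less inhibition), compound 1 gives 98%. In this assay compound 2 gives 102%. The two numbers sit within the usual scatter of each other, so the inhibition in this assay is level between compound 1 and compound 2 at the concentration tested.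

Compound 3 `Cn1ccc2cc(-c3cnccc3/C=C/C(=O)N3CCOCC3)ccc21` has not yet been measured. It differs from compound 2 in one place (morpholin-4-yl in place of hydroxy on a carbonyl carbon). Compound 1, which ends in a cyclic amide, gives 98% in this assay. On that basis the change is expected to make little difference, and the step of a number 6 percentage points lower from compound 2 to compound 3 (within the scatter) is expected to lie within the scatter, without direction beyond it. For compound 3 in this assay the estimate is 96%, with a range from 80% to 105%.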

Compound 3, a percentage reported as inhibition, at one concentration (the size of the read-out at that concentration, not a potency): 97%
Estimate against measurement, compound 3: 1 percentage points below, and the stated range covers the measured number.
By their numbers in this assay, from the lowest: compounds 3, 1 and 2 (each within the scatter of the next).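

In this assay, putting morpholin-4-yl in place of hydroxy on a carbonyl carbon gives a number 5 percentage points lower from compound 2 to compound 3 (within the scatter). This is the first pair shown that differs in one place only, and it indicates that, at the concentration tested, inhibition does not depend on the hydroxy of the carboxy group, with its hydrogen-bond donor, since the morpholin-4-yl amide, with no such donor and a six-membered ring in its place, reads level with the acid. The data shown offer no measurement that explains this result.

The compounds shown leave open whether other groups on the same carbonyl carbon, such as piperidin-1-yl, a dimethylamino group or a methoxy group forming an ester, would also read level with compound 2 and compound 3. These readings also come from a single concentration and are not potencies, so a full concentration series would be needed to tell whether compound 2 and compound 3 remain level at lower concentrations.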